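Compound 4: hydrogen in place of 4-methylphenyl

A few compounds are considered here, and "the series" means these few. Any claim that something is new, unique, unknown or untested is made for them only; others in the source may bear on it.

Compound 1 `CCN(CC)CN1C(=O)/C(=N/NC(=S)Nc2ccc(Cl)cc2)c2ccccc21`, compound 2 `CCN(CC)CN1C(=O)/C(=N/NC(=S)Nc2ccccc2)c2ccccc21` and compound 3 `CCN(CC)CN1C(=O)/C(=N/NC(=S)Nc2ccc(C)cc2)c2ccccc21` share one core and differ only in a single group on the aromatic ring. In a functional assay on L1210 cells (Mus musculus) for inhibition, read by cell counting, with a stated time of 48 h (a lower number here means a stronger inhibitor, a higher number a weaker inhibitor), compound 1 gives 11000 nM and compound 2 gives 13000 nM, and a 1.2-fold higher number from compound 1 to compound 2 (0.07 log units; within the scatter) stays within the scatter. Compound 3 gives 29000 nM, the highest number of the three, with modest steps in a 2.2-fold higher number from compound 2 to compound 3 (0.35 log units; beyond the scatter) and a 2.6-fold higher number from compound 1 to compound 3 (0.42 log units; beyond the scatter).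

Compound 4 `CCN(CC)CN1C(=O)/C(=N/NC(N)=S)c2ccccc21` carries hydrogen in place of 4-methylphenyl on an amide-type nitrogen. Among the measured compounds shown here, no measured step removes the aromatic ring, so the three steps bear on this change only indirectly. The largest of them is a 2.6-fold higher number from compound 1 to compound 3 (0.42 log units; beyond the scatter). The data therefore give no direction in this assay, and no step beyond the scatter is expected, though with low confidence. The estimated change is a 1.2-fold higher number from compound 3 to compound 4 (0.08 log units; within the scatter). For compound 4 the expected value is 35000 nM, with an estimated range of 10000 nM to 120000 nM.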

Compound 4, half-maximal inhibitory concentration: 121000 nM
The estimate for compound 4 lay 3.5-fold (0.54 log units) below the measured number; the measured number lies above the stated range.
By their numbers in this assay, from the lowest: compounds 1 and 2 (each within the scatter of the next); then compound 3; then compound 4.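

In this assay, the aryl group on the amide-type nitrogen turns out to matter more than the earlier ring substituent steps suggested: with hydrogen there, the number rises in every comparison (a 4.2-fold higher number from compound 3 to compound 4 (0.62 log units; beyond the scatter)) (a 9.3-fold higher number from compound 2 to compound 4 (0.97 log units; beyond the scatter)) (an 11-fold higher number from compound 1 to compound 4 (1.04 log units; beyond the scatter)). Among the compounds shown here, all three steps lie beyond the scatter, and the one from the 4-chlorophenyl compound is large, so compounds 1, 2 and 3 all give lower numbers than compound 4 whichever aryl group they carry. Nothing available on this series explains the rise.

The compounds shown leave open whether an aromatic ring is needed on this nitrogen or whether a methyl group, a longer chain such as butyl, or a saturated cyclohexyl ring would serve as well. On these data alone, a benzyl group, which would set the phenyl ring one carbon further out, remains equally open.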